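The compounds below may be only part of what the source reports. "The series", "measured", "known", "first", "only" and "open" are said of these compounds alone.

Working notes on the series, values in a physicochemical assay for lipophilicity; a higher number here means a more lipophilic compound, a lower number a more polar compound:

- compound 1 `CCCC(CCC)C(=O)OCC1(CO)C/C(=C/c2ccncc2)C(=O)O1`: 2.9
- compound 2 `CC(C)CC(CC(C)C)C(=O)OCC1(CO)C/C(=C\c2ccccn2)C(=O)O1`: 3.79
- compound 3 `CN(C)c1ccc(C(=O)OCC2(CO)C/C(=C/c3ccncc3)C(=O)O2)cc1`: 2.07

Compound 1 holds the second highest of the three numbers, with compound 3 the nearest and compound 2 the furthest. The next compound, compound 4 `CCCC(CCC)C(=O)OCC1(CO)C/C(=C/c2cccnc2)C(=O)O1`, has the same atoms as compound 1, joined differently: pyridin-3-yl in place of pyridin-4-yl on a double-bonded chain carbon bound to a double-bonded ring carbon. The change is pyridin-3-yl in place of pyridin-4-yl on a double-bonded chain carbon bound to a double-bonded ring carbon.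

Within the data shown here, the one measured step in a single place is a number 0.83 log units lower from compound 1 to compound 3 (beyond the scatter). That step swaps 1-propylbutyl for 4-(dimethylamino)phenyl on a carbonyl carbon and leaves pyridin-4-yl untouched, so it gives a sense of scale only. Compound 2 differs from compound 1 in more than one place, so its value isolates no single change. Among the measured compounds shown here, no measured step in this set covers the place that changes in compound 4.

For the measured compounds named here, with the atoms unchanged and no measured step against it, no shift beyond the scatter is expected in this assay. The expected step is small, a number 0.05 log units higher from compound 1 to compound 4 (within the scatter). For compound 4 the estimated value is 2.95, with an expected range of 2.6 to 3.3.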

Compound 4, partition coefficient: 2.9
Compound 4: the middle estimate sits 0.05 log units above what was measured; measured number inside the range.
By their numbers in this assay, from the lowest: compound 3; then compounds 1 and 4 (each within the scatter of the next); then compound 2.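

In this assay, among these compounds, pyridin-3-yl in place of pyridin-4-yl on a double-bonded chain carbon bound to a double-bonded ring carbon gives no change at the digits printed from compound 1 to compound 4 (within the scatter), the first step read at this place, which no earlier pair covered. Among the compounds shown here, with 1-propylbutyl held fixed on the carbonyl carbon, this pair of pyridine attachments cannot be told apart in this assay, whereas the one earlier single-place step, at the carbonyl carbon, gives a number 0.83 log units lower from compound 1 to compound 3 (beyond the scatter) and lies beyond the scatter. Nothing measured here bears on why the two attachments read alike, so the flat step stands as an observation only.

On these data alone, compound 2 carries a third attachment pattern on its pyridine but differs from compound 1 in more than one place, so what a pyridin-2-yl group does at this place on its own remains open, as does whether the flat step holds with 4-(dimethylamino)phenyl on the carbonyl carbon. Also open, as far as these compounds go, is whether a plain phenyl, or a pyridine ring carrying an amine or a carboxylic acid, would stay as close to compound 1 at this place as the pyridin-3-yl group of compound 4 does.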